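The source may hold more compounds than are shown below. What is called first, only, known or untested is meant among the compounds shown, and "the series" means these compounds.

In a functional assay (aorta) with Oryctolagus cuniculus as the target (a lower number here means a stronger inhibitor, a higher number a weaker inhibitor), compound 3 `OCc1ccc(-c2nn(Cc3c(F)cccc3F)c3ccccc23)o1` gives 15000 nM, the highest of the two single numbers here; its nearest neighbour, compound 2 `OCc1ccc(-c2nn(Cc3cccc(F)c3)c3ccccc23)o1`, gives 10000 nM, and compound 1 `OCc1ccc(-c2nn(Cc3ccccc3F)c3ccccc23)o1` gives 4900 nM; 4900 nM (2 entries). Within the data shown here, the step of a 1.5-fold higher number from compound 2 to compound 3 (0.18 log units; within the scatter) is the only one-place change among the measured compounds, and it stays within the scatter. Compound 4 `OCc1ccc(-c2nn(Cc3cccnc3)c3ccccc23)o1` differs from compound 3 by pyridin-3-yl in place of 2,6-difluorophenyl on a saturated chain carbon bound to an aromatic nitrogen. Among the measured compounds shown here, no measured step replaces a fluorinated phenyl group by a pyridine at this position, so nothing here bears directly on the change. The numbers do not support a prediction of a step beyond the scatter in either direction in this assay. Compound 4 is therefore expected near compound 3, at an estimated 15000 nM with a range of 5000 nM to 45000 nM, corresponding to an expected step of no change at the digits printed from compound 3 to compound 4 (within the scatter).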

Compound 4, half-maximal inhibitory concentration: 9600 nM
The estimate for compound 4 lay 1.6-fold (0.19 log units) above the measured number; the range from low to high includes it.
By their numbers in this assay, from the lowest: compounds 4, 2 and 3 (each within the scatter of the next).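

In this assay, the step to pyridin-3-yl reads as a 1.6-fold lower number from compound 3 to compound 4 (0.19 log units; within the scatter) and, set against the 3-fluorophenyl group, as a 1.0-fold lower number from compound 2 to compound 4 (0.02 log units; within the scatter) in the same place on the saturated chain carbon bound to an aromatic nitrogen. The position therefore takes a six-membered aromatic ring with a hetero atom in place of either fluorinated ring without a step beyond the scatter. Nothing available explains this result. The compounds shown leave open whether pyridin-4-yl, a piperidine or a longer chain on the aromatic nitrogen would give a step beyond the scatter.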